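Lengthening the amide chain on a sulfonate ester

The source may report more compounds than this note shows. Statements on the series, on what has been measured and on what is new or still open speak of the compounds shown alone.

Measured compounds:
compound 1, `CCC(=O)Nc1ccc(S(=O)(=O)Oc2ccccc2C(C)C)cc1`, 11000 nM
compound 2, `CCC(=O)Nc1ccc(S(=O)(=O)Oc2ccccc2I)cc1`, 8100 nM

Both compounds were tested in a functional assay on MCF7 cells (Homo sapiens) for antiproliferative activity, read by sulforhodamine B assay, with a stated time of 48 h; a higher number here means a weaker inhibitor, a lower number a stronger inhibitor. Within the data shown here, compound 1 gives 11000 nM and compound 2 gives 8100 nM; the only measured step, a 1.4-fold lower number from compound 1 to compound 2 (0.13 log units; within the scatter), so the two values cannot be told apart. Compound 2 stands at the lower of the two numbers, but within the scatter of compound 1.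

Compound 3, `CCCC(=O)Nc1ccc(S(=O)(=O)Oc2ccccc2I)cc1`, differs from compound 2 by methyl in place of hydrogen on a saturated chain carbon, two bonds along the chain from a carbonyl carbon. Among the measured compounds shown here, no measured step touches this part of the molecule: the one step on record changes the group on the aromatic ring and it was within the scatter. There is therefore nothing to suggest a shift beyond the scatter in this assay for compound 3, in either direction.

Compound 3 is expected to give roughly 7500 nM in this assay, with a range from 3000 nM to 19000 nM, that is an expected step of a 1.1-fold lower number from compound 2 to compound 3 (0.03 log units; within the scatter), within the scatter.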

Compound 3, half-maximal inhibitory concentration: 9700 nM
For compound 3 the middle estimate is 1.3-fold (0.11 log units) below the measured one; the range from low to high includes it.
By their numbers in this assay, from the lowest: compounds 2, 3 and 1 (each within the scatter of the next).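

Extending the amide chain from propanoyl to propylcarbonyl gives a 1.2-fold higher number from compound 2 to compound 3 (0.08 log units; within the scatter) in this assay and so produces no readable change. Among these compounds, until now, the only measured change was on the aromatic ring; this result adds that a methyl in place of hydrogen on a saturated chain carbon, two bonds along the chain from a carbonyl carbon, also leaves the value within the scatter, so compounds 2 and 3 cannot be told apart. This is one single-carbon change in one cell assay, and nothing measured here bears on why the value stays within the scatter.

The compounds shown leave open whether the chain can grow much further, for example to a hexanoyl or octanoyl group, or whether an amine or a carboxylic acid at its end would move the value beyond the scatter. They also leave open whether the same methyl in place of hydrogen would give a similarly small step on the isopropyl compound, compound 1, since the chain change is shown only alongside iodo.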